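A few compounds are considered here, and "the series" means these few. Any claim that something is new, unique, unknown or untested is made for them only; others in the source may bear on it.

Measured compounds:
Compound 1, `Cc1ccc2[nH]c(C(=O)N[C@H]3CN(S(=O)(=O)c4ccnc(C)c4)C[C@@H]3C(=O)NCCN(C)C)cc2c1`, gives 91% in a functional assay on HEK293 cells for agonist activity at growth hormone secretagogue receptor type 1 (Homo sapiens), read by HTRF and inositol phosphate accumulation, with a stated time of 90 min, in the presence of a further agent that is not named here; a higher number here means a larger maximal response, a lower number a smaller maximal response.
Compound 2, `Cc1ccc2[nH]c(C(=O)N[C@H]3CN(S(=O)(=O)c4cn(C)nc4C)C[C@@H]3C(=O)NCCN(C)C)cc2c1`, gives 95% in this assay.
Compound 3, `Cc1ccc2[nH]c(C(=O)N[C@H]3CCN(S(=O)(=O)c4cccnc4)C[C@@H]3C(=O)NCCN(C)C)cc2c1`, gives 93% in this assay.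

All three numbers lie within the usual scatter of one another, so none of the compounds can be called the strongest or weakest. Compound 3 sits between the other two, close to compound 1 and equally close to compound 2. Going by the values given here, the one step between compounds that differ in a single place, a number 4 percentage points higher from compound 1 to compound 2 (within the scatter), stays within the scatter: exchanging the group on the sulfonyl sulfur left the maximal response essentially unchanged.

Compound 4, `Cc1ccc2[nH]c(C(=O)N[C@H]3CCN(S(=O)(=O)N4CCOCC4)C[C@@H]3C(=O)NCCN(C)C)cc2c1`, differs from compound 3 only on that same sulfonyl sulfur: morpholin-4-yl in place of pyridin-3-yl on a sulfonyl sulfur. Among the compounds with values here, the step from compound 1 to compound 2 is the only measured change at this position, and it was within the scatter, so no movement beyond the scatter is expected in this assay for compound 4, that is a number 3 percentage points lower from compound 3 to compound 4 (within the scatter). Compound 4 is therefore estimated at 90%, with a range from 75% to 100%.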

Compound 4, largest response reached (Emax), in percent of the reference or control that the assay uses: 98%
The estimate for compound 4 lay 8 percentage points below the measured number, and the stated range covers the measured number.
By their numbers in this assay, from the lowest: compounds 1, 3, 2 and 4 (each within the scatter of the next).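

Going by these compounds alone, until now, the only exchange measured on the sulfonyl sulfur replaced one aromatic ring with another, whereas morpholin-4-yl brings a six-membered non-aromatic ring containing oxygen. Even so, this assay gives a number 5 percentage points higher from compound 3 to compound 4 (within the scatter), so in this pair the aromatic ring of pyridin-3-yl is not needed to keep the maximal response within the scatter. Nothing available explains why the response holds across this exchange.

The compounds shown leave open whether a much smaller group on the sulfonyl sulfur, such as methyl or dimethylamino, or a ring carrying a carboxylic acid, would keep the response as well. They also leave open how much compound is needed to reach this response, as a maximal response does not show that.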